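A Fluorine Swap on Two Related Indole Cores

The compounds below may be only part of what the source reports. "The series", "measured", "known", "first", "only" and "open" are said of these compounds alone.

Measured so far in a functional assay on MCF7 cells (Homo sapiens) for cytotoxicity, read by MTT assay, with a stated time of 2 days; a higher number here means that more compound is tolerated, a lower number that less compound is tolerated:
- compound 1, `COc1ccc(-c2cc(C(C)=O)c3[nH]c(-c4ccccc4)cc3c2)cc1`, gives 47800 nM
- compound 2, `COc1ccc(-c2cc(C(C)=O)c3[nH]c(-c4ccc(F)cc4)cc3c2)cc1`, gives 16800 nM
- compound 3, `COc1ccc(-c2cc3cc(-c4ccccc4)cc(C(C)=O)c3[nH]2)cc1`, gives > 100000 nM, which is a limit of the assay and not a number

Compound 1 and compound 2 differ by one change, (fluoro in place of hydrogen on an aromatic carbon), and this step is a 2.8-fold lower number from compound 1 to compound 2 (0.45 log units; beyond the scatter). Compound 3 has the same atoms as compound 1 joined differently; the difference between the two cores is not broken down here.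

Compound 4, `COc1ccc(-c2cc3cc(-c4ccc(F)cc4)cc(C(C)=O)c3[nH]2)cc1`, is not yet measured. Going by the values given here, it differs from compound 3 by fluoro in place of hydrogen on an aromatic carbon, the same change as the one from compound 1 to compound 2, at a place described in the same words. In this assay compound 3 sits at the limit of > 100000 nM in this assay, at which 1 of the 3 values shown sits, so only the direction of the earlier step can be carried over. Compound 4 is expected to fall near 60000 nM, within 25000 nM to 150000 nM. That estimate means a step of an at least 1.6-fold lower number from compound 3 to compound 4 (0.22 log units; that floor lies within the scatter), resting on a 2.8-fold lower number from compound 1 to compound 2 (0.45 log units; beyond the scatter).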

Compound 4, concentration lethal to 50% of the cells: > 100000 nM
Compound 4 gave a limit, no number (the forecaster's own chance of this, stated with the estimate: 45%); at least 1.6-fold (0.22 log units) between middle value and limit.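

Compound 3 and compound 4 both sit at the same limit of the assay in this assay, not at numbers, so no step between them can be read: the limit of > 100000 nM in this assay, at which 2 of the 4 values shown sit.

The compounds shown leave open whether going from phenyl to 4-fluorophenyl changes the number on the core of compound 3, as it does on the core of compound 1.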